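Anilino to phenoxy on the shared core

A few compounds are considered here, and "the series" means these few. Any claim that something is new, unique, unknown or untested is made for them only; others in the source may bear on it.

In an ADME assay (liver) for metabolic stability, with Liver microsome (Rattus norvegicus) as the target, using microsomes and NADPH, with a stated time of 30 min, at 37 degrees C, tested at 1 uM (on this read-out higher numbers stand for fast clearance and lower numbers for slow clearance), compound 1 `CC(C)Nc1nc(S(=O)(=O)c2ccc(N)nc2)ccc1-c1ccc(C(C)(O)C(F)(F)F)cn1` gives 62 mL.min-1.g-1. Compound 2 `CC(O)(c1ccc(-c2ccc(S(=O)(=O)c3ccc(N)nc3)nc2Nc2ccccc2)nc1)C(F)(F)F`, with phenyl in place of isopropyl on a nitrogen on an aromatic ring, gives 100 mL.min-1.g-1. The step between them is a 1.6-fold higher number from compound 1 to compound 2 (0.21 log units; within the scatter), so compound 2 stands level with compound 1, and these two numbers do not separate them.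

The change now in view starts from compound 2. Compound 3 `CC(O)(c1ccc(-c2ccc(S(=O)(=O)c3ccc(N)nc3)nc2Oc2ccccc2)nc1)C(F)(F)F` has phenoxy in place of anilino on an aromatic carbon. The swap lies next to the ring nitrogen and ortho to a large group.

Among the measured compounds shown here, only one measured step bears on this change: a 1.6-fold higher number from compound 1 to compound 2 (0.21 log units; within the scatter). For the measured compounds named here, it exchanged isopropyl for phenyl on a nitrogen, and no measured compound carries phenoxy, so it offers only an indirect guide. With that single step inside the scatter, no step beyond the scatter is expected in this assay, and no direction is favoured. The estimated step is a 1.1-fold lower number from compound 2 to compound 3 (0.05 log units; within the scatter). Compound 3 is expected at 90 mL.min-1.g-1, with an estimated range of 45 mL.min-1.g-1 to 180 mL.min-1.g-1.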

Compound 3, intrinsic clearance in microsomes: 213 mL.min-1.g-1
The estimate for compound 3 lay 2.4-fold (0.37 log units) below the measured number; the measured number lies above the stated range.
By their numbers in this assay, from the lowest: compounds 1 and 2 (each within the scatter of the next); then compound 3.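

In this assay this position responds to the atom that links the aromatic ring to the core, which the earlier pair could not show: with a 2.1-fold higher number from compound 2 to compound 3 (0.33 log units; beyond the scatter) the step is modest but beyond the scatter, while changing the group on the nitrogen gave a 1.6-fold higher number from compound 1 to compound 2 (0.21 log units; within the scatter) and stayed within it. The other comparison, with a 3.4-fold higher number from compound 1 to compound 3 (0.54 log units; beyond the scatter), is also beyond the scatter and of modest size, so compound 3 stands clear of both other compounds as the fastest-clearing of the three on this read-out. The exchange keeps the six-membered carbon ring and the heavy-atom count, and the count that changes is hydrogen-bond donors, 1 for anilino and 0 for phenoxy, but nothing shown ties the higher clearance to that difference or to any other cause.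

From the compounds shown here alone, it remains open whether the higher number follows the oxygen link in general or only this link together with the phenyl ring, and an isopropoxy group at this place would test that against compound 1 and compound 3. A benzyl group or a phenylthio group would show whether the trend extends to other links.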